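The compounds below may be only part of what the source reports. "The series", "measured", "known", "first", "only" and "open" are said of these compounds alone.

Working notes on the series. For the measured compounds named here, in an ADME assay (liver) for metabolic stability, with Liver microsome (Rattus norvegicus) as the target, read by LC-MS, using microsomes and NADPH, with stated times of 5 min and 60 min, tested at 4 uM (a lower number here means that less of the compound is left, a higher number that more of the compound is left), compound 1 (`COc1cc(C(=O)O)ccc1OCCCCOc1ccc(C(=O)CC(C)C)c(O)c1C`) gives 43% and holds the lower of the two numbers so far, with compound 2 (`Cc1c(OCCCCOc2ccc(C(=O)O)cc2Cl)ccc(C(=O)CC(C)C)c1O`) at 61% as its only neighbour. Compound 3 (`COc1cc(C(=O)O)ccc1OCCCCOc1ccc(C(=O)CC(C)(C)C)c(O)c1C`) is still unmeasured in this assay and differs from compound 1 by methyl in place of hydrogen on a saturated chain carbon bound to three saturated chain carbons as methyl in place of hydrogen on a saturated chain carbon bound to three saturated chain carbons, which also reads as isobutylcarbonyl to neopentylcarbonyl. Going by the values given here, the only measured step, a number 18 percentage points higher from compound 1 to compound 2 (beyond the scatter) for chloro in place of methoxy on an aromatic carbon, is modest and lies at a different place in the structure. It therefore shows only how far one change has moved this assay in this pair. Among the compounds with values here, no measured step touches the isobutylcarbonyl group, so the estimate rests on little and its range stays wide. A small rise is expected rather than a large move in either direction. The expected step is a number 7 percentage points higher from compound 1 to compound 3 (within the scatter) and no more than that is assumed. For compound 3 the estimated value is 50% with an expected range from 33% to 67% in this read-out.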

Compound 3, percent of the compound remaining: 49%
For compound 3 the middle estimate is 1 percentage points above the measured one, within the range that was stated.
By their numbers in this assay, from the lowest: compounds 1 and 3 (each within the scatter of the next); then compound 2.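

In this assay, for the compounds shown here, the isobutylcarbonyl group of compound 1 can now be read for the first time: the change to neopentylcarbonyl, methyl in place of hydrogen on a saturated chain carbon bound to three saturated chain carbons, gives a number 6 percentage points higher from compound 1 to compound 3 (within the scatter) and so does not separate the pair. Going by these compounds alone, the only earlier step, chloro in place of methoxy on an aromatic carbon, gives a number 18 percentage points higher from compound 1 to compound 2 (beyond the scatter) and lies at a different place, so the side of the molecule carrying this chain now has a reading of its own, with one added methyl leaving the two compounds within the usual scatter. Nothing at hand bears on the reason for this result.

As far as these compounds go, whether isobutyl to neopentyl gives a similar reading with chloro in place of methoxy remains open, as compound 2 carries only the isobutylcarbonyl group. Also open, from the compounds shown here alone, is what a longer chain, a cyclopropyl group or an amine at this chain carbon would do in this assay for the core of compound 1.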